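The source may report more compounds than this note shows. Statements on the series, on what has been measured and on what is new or still open speak of the compounds shown alone.

Compound 2 `CN1CCN(CCCOc2cccc3nc(Nc4ccc(Cl)c(F)c4)ccc23)CC1` stands at the higher of the two numbers measured: in a functional assay on cells (Panel renal (Carcinoma cell lines), Homo sapiens) for inhibition, read by sulforhodamine B assay, with a stated time of 48 h (a higher number here means that more compound is tolerated, a lower number that less compound is tolerated), compound 2 gives 19800 nM. Going by the values given here, its only neighbour, compound 1 `CN1CCN(CCCOc2cccc3nc(Nc4ccc(Cl)c(C(F)(F)F)c4)ccc23)CC1`, gives 6460 nM, and the step of a 3.1-fold higher number from compound 1 to compound 2 (0.49 log units; beyond the scatter) came from fluoro in place of trifluoromethyl on an aromatic carbon. Compound 3 `CN1CCN(CCCOc2cccc3nc(Nc4cccc(Cl)c4)ccc23)CC1` differs from compound 2 by 3-chlorophenyl in place of 4-chloro-3-fluorophenyl on a nitrogen on an aromatic ring. No measured step removes a fluorine in this way, so the one step shown offers only loose guidance, and for compound 3 the expected step of a 1.1-fold higher number from compound 2 to compound 3 (0.05 log units; within the scatter) is none beyond the scatter. Compound 3 is therefore estimated at 22000 nM, within 8000 nM to 60000 nM.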

Compound 3, concentration lethal to 50% of the cells: 17400 nM
Beside the measured number, compound 3's estimate is 1.3-fold (0.10 log units) above it, and the stated range covers the measured number.
By their numbers in this assay, from the lowest: compound 1; then compounds 3 and 2 (each within the scatter of the next).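

Swapping 4-chloro-3-fluorophenyl for 3-chlorophenyl on this nitrogen gives a 1.1-fold lower number from compound 2 to compound 3 (0.06 log units; within the scatter), so in this assay this change makes no difference that can be told from the scatter. Swapping 4-chloro-3-(trifluoromethyl)phenyl for the same 3-chlorophenyl gives a 2.7-fold higher number from compound 1 to compound 3 (0.43 log units; beyond the scatter), so among these three compounds, only compound 1 stands apart, with the lowest number. No measurement offered here explains why the trifluoromethyl compound differs. Still open, from the compounds shown here alone, is how a phenyl ring with no halogen, or one carrying a methoxy group or a nitrile, would behave at this position.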